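From 2-bromophenyl to 4-bromophenyl on the shared core

The source may report more compounds than this note shows. Statements on the series, on what has been measured and on what is new or still open speak of the compounds shown alone.

Measured in a functional assay on SGC-7901 cells (Homo sapiens) for antiproliferative activity, read by sulforhodamine B assay, with a stated time of 72 h; on this read-out lower numbers stand for stronger inhibition and higher numbers for weaker inhibition:
- compound 1 `Cc1ccccc1NC(=S)N/N=C/c1ccc2ccccc2n1`: > 100000 nM
- compound 2 `S=C(N/N=C/c1ccc2ccccc2n1)Nc1ccccc1Br`: > 100000 nM

Compound 2 gives > 100000 nM in this assay, which is a limit and not a number. Compound 1 gives > 100000 nM, which is also a limit. Among the compounds with values here, the series so far therefore rests on (the limit of > 100000 nM in this assay, at which 2 of the 2 values shown sit), and compound 2 has no measured rank.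

The next structure is compound 3 `S=C(N/N=C/c1ccc2ccccc2n1)Nc1ccc(Br)cc1`. The change is 4-bromophenyl in place of 2-bromophenyl on an amide-type nitrogen. The same atoms are joined differently, with 4-bromophenyl in place of 2-bromophenyl on an amide-type nitrogen.

Within the data shown here, the only measured step is a step that the two limits leave unreadable from compound 1 to compound 2. That step is bromo in place of methyl on an aromatic carbon, a different change, and it has no readable size. Among the measured compounds shown here, no measured step sets the size or direction here. Any number reported for compound 3 is expected on the side of stronger inhibition, and another limit remains quite possible. The estimated step is an at least 5.0-fold lower number from compound 2 to compound 3 (0.69 log units; beyond the scatter). The estimate for compound 3 is 20000 nM, with an expected range from 2000 nM to 100000 nM.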

Compound 3, half-maximal inhibitory concentration: 69400 nM
Compound 3: the middle estimate sits 3.5-fold (0.54 log units) below what was measured; the measured number falls inside the stated range.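

In this assay, 4-bromophenyl in place of 2-bromophenyl on the amide-type nitrogen gives the series its first actual number, with an at least 1.4-fold lower number from compound 2 to compound 3 (0.15 log units; that floor lies within the scatter). With 4-bromophenyl in place of 2-methylphenyl at that same nitrogen, the result is an at least 1.4-fold lower number from compound 1 to compound 3 (0.15 log units; that floor lies within the scatter), so both steps are only floors, and neither floor by itself clears the usual scatter of this read-out. The result therefore shows that this nitrogen substituent can bring a compound on the shared core within measurable range, while the rest of the series remains at a limit and not at a number: the limit of > 100000 nM in this assay, at which 2 of the 3 values shown sit.

Within the data shown here, the true size of both steps remains open, as the two limits give only one end of each comparison, and a real difference between the 4-bromophenyl and 2-bromophenyl compounds cannot yet be separated from the scatter. Also open, as far as these compounds go, is whether the measurable value is particular to 4-bromophenyl or extends to other groups on the same amide-type nitrogen, such as 4-methylphenyl or 4-chlorophenyl, which would also set 4-bromophenyl against a close neighbour with a readable step.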